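The source may hold more compounds than are shown below. What is called first, only, known or untested is meant among the compounds shown, and "the series" means these compounds.

Measured so far:
Compound 1, `CSc1ccc(-c2nc3c(=O)n(C)c(=O)n(C)c3[nH]2)cc1`, gives 2 nM in an assay for binding affinity to adenosine receptor A1 (Bos taurus); a lower number here means a stronger inhibitor, a higher number a weaker inhibitor.
Compound 2, `Cn1c(=O)c2nc(-c3ccc(Cl)cc3)[nH]c2n(C)c1=O`, gives 0.8 nM in this assay.
Compound 3, `CCCn1c(=O)c2nc(-c3ccccc3N)[nH]c2n(CCC)c1=O`, gives 0.75 nM in this assay.

Among these three numbers compound 2 stands second highest. Its nearest neighbour is compound 3, whose number lies within the scatter of its own, so the two cannot be told apart. Compound 1 stands furthest away: the step of a 2.5-fold lower number from compound 1 to compound 2 (0.40 log units; beyond the scatter) shows that swapping methylsulfanyl for chloro on the aromatic carbon lowered the number, a modest change beyond the scatter.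

The next compound, compound 4, `CN(C)c1ccc(-c2nc3c(=O)n(C)c(=O)n(C)c3[nH]2)cc1`, differs from compound 2 in one place: dimethylamino in place of chloro on an aromatic carbon. Among the measured compounds shown here, only the step from compound 1 to compound 2 bears on this position, and it shows that a group swap there can move the number by a modest amount. Dimethylamino has not been tried here, so the direction is uncertain. A small rise in the number is expected, a 2.5-fold higher number from compound 2 to compound 4 (0.40 log units; beyond the scatter), giving for compound 4 an estimated 2 nM in this assay, within a range of 0.5 nM to 8 nM.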

Compound 4, half-maximal inhibitory concentration: 1.8 nM
Estimate against measurement, compound 4: 1.1-fold (0.05 log units) above; measured number inside the range.
By their numbers in this assay, from the lowest: compounds 3 and 2 (each within the scatter of the next); then compounds 4 and 1 (each within the scatter of the next).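

On this aromatic carbon in this assay, the move to dimethylamino gives a 2.3-fold higher number from compound 2 to compound 4 (0.35 log units; beyond the scatter) and so shows that chloro also stands apart from a second group, not only from methylsulfanyl. Dimethylamino and methylsulfanyl themselves cannot be told apart, with a 1.1-fold lower number from compound 1 to compound 4 (0.05 log units; within the scatter) as their step, so among these three groups on the shared core only chloro separates from the others. Nothing shown here explains why chloro differs from these two groups.

Going by these compounds, whether a carboxylic acid, a hydroxyl group, a longer alkyl chain or plain hydrogen at this place would fall with chloro or with the other two remains open. Compound 3 differs from these compounds in more than one place, so it cannot show whether the same order holds on a core with longer chains.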